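This account rests on a few compounds, and the source may have more. Where it says the series, first, only, none or still open, it means among the compounds named here.

Compound 2 `COc1ccc(-c2nc(CNC(=O)NC(C)C)sc2-c2ccc(OC)cc2)cc1` gives 5.7 uM in a functional assay (aorta) with Rattus norvegicus as the target; a lower number here means that less compound is needed, a higher number that more compound is needed for the effect. Of the two numbers measured, compound 2 stands alongside compound 1 `COc1ccc(-c2nc(CNC(=O)CSC)sc2-c2ccc(OC)cc2)cc1`, which gives 6 uM; the two are within the scatter of each other. Among the compounds with values here, the single measured step, a 1.1-fold lower number from compound 1 to compound 2 (0.02 log units; within the scatter), lies within the scatter. Compound 3 `CCOC(=O)/C=C/c1nc(-c2ccc(OC)cc2)c(-c2ccc(OC)cc2)s1` differs from compound 2 in that (2-(ethoxycarbonyl)ethenyl in place of ((isopropylcarbamoyl)amino)methyl on an aromatic carbon). Within the data shown here, no measured step covers this change, so its size cannot be read from the data. Compound 3 is therefore expected to land near compound 2, with a 1.8-fold higher number from compound 2 to compound 3 (0.24 log units; within the scatter), and its value is estimated at 10 uM, in a range from 2.5 uM to 40 uM.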

Compound 3, concentration for half-maximal effect: > 100 uM
Compound 3: no number, only a limit (the forecaster's own chance of this, stated with the estimate: 20%); at least 10-fold (1.00 log units) between middle value and limit.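

On the aromatic carbon next to the ring nitrogen and the ring sulfur, the two earlier side chains lay within the scatter of each other, but this position does not accept every group in this assay. Placing 2-(ethoxycarbonyl)ethenyl there gives an at least 17-fold higher number from compound 2 to compound 3 (1.24 log units; beyond the scatter) and an at least 16-fold higher number from compound 1 to compound 3 (1.22 log units; beyond the scatter). The value of compound 3 is a limit, not a number: the limit of > 100 uM in this assay, at which 1 of the 3 values shown sits.

On these data alone, the full size of the step therefore stays open. Also open, as far as these compounds go, is whether the ethenyl link or the ethyl ester accounts for it, which a saturated chain bearing the same ester or a carboxylic acid in place of the ester could separate.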